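The source may report more compounds than this note shows. Statements on the series, on what has been measured and on what is new or still open speak of the compounds shown alone.

Measured compounds:
- compound 1 `Cc1cc(C#N)cc(C)c1Oc1ccnc(S(=O)(=O)CC(=O)Nc2ccccc2)n1`, in an ADME assay on MT4 cells (Homo sapiens) for cytotoxicity, read by MTT assay, with a stated time of 4 days (on this read-out lower numbers stand for higher toxicity in this test and higher numbers for lower toxicity in this test), compound 1 gives 29300 nM
- compound 2 `COc1ccc(NC(=O)CS(=O)(=O)c2nccc(Oc3c(C)cc(C#N)cc3C)n2)cc1`, in this assay compound 2 gives 5110 nM

Going by the values given here, compound 2 stands at the lowest of the two numbers measured so far; the only other value is that of compound 1, and the step of a 5.7-fold lower number from compound 1 to compound 2 (0.76 log units; beyond the scatter) separates them.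

Compound 3 `Cc1cc(C#N)cc(C)c1Oc1ccnc(S(=O)(=O)CC(=O)Nc2ccc(Br)cc2)n1` is the next compound in this series. It differs from compound 2 in one place: bromo in place of methoxy on an aromatic carbon.

Among the compounds with values here, no measured step bears directly on an exchange of methoxy for bromo. Within the data shown here, the single step known, a 5.7-fold lower number from compound 1 to compound 2 (0.76 log units; beyond the scatter), concerns the same position on the phenyl ring and shows that a group placed there can move the number in this assay by a modest amount. Whether bromo behaves more like methoxy or more like hydrogen at that position cannot be read from these two compounds. The expected step of a 1.6-fold higher number from compound 2 to compound 3 (0.19 log units; within the scatter) is therefore left without a clear direction and lies within the usual scatter. Compound 3 is estimated at 8000 nM, with a range from 2500 nM to 25000 nM.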

Compound 3, half-maximal cytotoxic concentration: 15600 nM
For compound 3 the middle estimate is 2.0-fold (0.29 log units) below the measured one, within the range that was stated.
By their numbers in this assay, from the lowest: compound 2; then compounds 3 and 1 (each within the scatter of the next).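

In this assay, exchanging methoxy for bromo at this aromatic carbon, para to a large group, gives a 3.1-fold higher number from compound 2 to compound 3 (0.48 log units; beyond the scatter), so the number at this position depends on which group is present and not merely on whether a group is present. Going by these compounds alone, the step of a 1.9-fold lower number from compound 1 to compound 3 (0.27 log units; within the scatter) shows that bromo in place of hydrogen stays within the scatter, which leaves compound 3 indistinguishable from compound 1 and makes compound 2 the only one of the three set apart, with methoxy as the only group here whose effect on the number exceeds the scatter. Methoxy carries one hydrogen-bond acceptor and bromo none by the count, but no measurement at hand explains why the two groups differ in this test.

On these data alone, it remains open whether other groups at this place, such as an amine, a carboxylic acid or a longer alkoxy chain like ethoxy, would follow methoxy or would stay with hydrogen and bromo. Also unsettled is whether the same exchange of methoxy for bromo would give a similar step at another carbon of this ring or on a different core.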